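Nitro for hydrogen on the aryl ring across two cores

The compounds below may be only part of what the source reports. "The series", "measured", "known", "first", "only" and "open" are said of these compounds alone.

Compound 1 `CN1C(=O)N(C)C2C1NC(=S)N2/N=C/C=C/c1ccccc1` and compound 2 `CN1C(=O)N(C)C2C1NC(=S)N2/N=C/C=C/c1ccccc1[N+](=O)[O-]` share one core; compound 3 `CCN1C(=O)N(CC)C2C1N=C(SC)N2/N=C/C=C/c1ccccc1` and compound 4 `CCN1C(=O)N(CC)C2C1N=C(SC)N2/N=C/C=C/c1ccccc1[N+](=O)[O-]` share another, and the difference between the two cores is not broken down here. In a functional assay on A549 cells (Homo sapiens) for inhibition, read by MTT assay, with a stated time of 72 h (on this read-out lower numbers stand for stronger inhibition and higher numbers for weaker inhibition), compound 1 gives 45700 nM and compound 2 gives 2720 nM. The change between them, (nitro in place of hydrogen on an aromatic carbon), brought a 17-fold lower number from compound 1 to compound 2 (1.23 log units; beyond the scatter). In this assay compound 3 gives 21400 nM, which stands between the other two: against compound 1 the number is lower beyond the scatter, against compound 2 it is higher beyond the scatter. Among the measured compounds shown here, the change from compound 3 to compound 4 is nitro in place of hydrogen on an aromatic carbon, the same change as the one from compound 1 to compound 2, here made on the other core. For the measured compounds named here, for compound 4 the expected step is a 14-fold lower number from compound 3 to compound 4 (1.15 log units; beyond the scatter), resting on the single precedent a 17-fold lower number from compound 1 to compound 2 (1.23 log units; beyond the scatter); with one example only and a different core, a somewhat smaller step than that precedent is expected. Compound 4 is therefore estimated at 1500 nM in this assay, with a range from 500 nM to 6000 nM.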

Compound 4, half-maximal inhibitory concentration: > 100000 nM
Compound 4: only a limit was reported; the forecaster's own chance of this, stated with the estimate: 3%; middle value at least 66-fold (1.82 log units) from the limit.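

In this assay compound 4 gives > 100000 nM, which is a limit of the assay and not a number. The step reads an at least 4.6-fold higher number from compound 3 to compound 4 (0.66 log units; beyond the scatter), so in these two pairs nitro in place of hydrogen on an aromatic carbon does not carry over from the core of compound 1 to the core of compound 3, and the direction of the step reverses: the same change on two cores in this assay, a 17-fold lower number (1.23 log units; beyond the scatter) from compound 1 to compound 2 and an at least 4.6-fold higher number (0.66 log units; beyond the scatter) from compound 3 to compound 4, at least 78-fold (1.89 log units) apart, beyond the scatter of two such steps. This does not show which feature of the two cores goes with the reversal, gives no rule beyond these two pairs, and leaves the full size of the step unfixed: the limit of > 100000 nM in this assay, at which 1 of the 4 values shown sits.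

Open, from the compounds shown here alone, is which part of the core difference matters, since the cores of compound 1 and compound 3 are compared here only as wholes. Also open, going by these compounds, is whether an amine or a carboxylic acid in place of the nitro would follow the pattern of compound 2 or that of compound 4.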